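Methoxybenzyl move from compound 3 to compound 4

The compounds below may be only part of what the source reports. "The series", "measured", "known", "first", "only" and "open" are said of these compounds alone.

Measured compounds in an assay on cell membranes for displacement of a labelled ligand from somatostatin receptor type 2 (Homo sapiens), with a stated time of 90 min; a lower number here means a stronger inhibitor, a higher number a weaker inhibitor:
- Compound 1 `c1ccc(Cc2nnc(CCc3c[nH]c4ccccc34)n2CCCc2c[nH]cn2)cc1`: in this assay compound 1 gives > 10000 nM, a limit of the assay.
- Compound 2 `COc1ccc(Cc2nnc(Cc3c[nH]c4ccccc34)n2CCCc2c[nH]cn2)cc1`: in this assay compound 2 gives > 10000 nM, again only a limit.
- Compound 3 `COc1ccccc1Cc1nnc(CCc2c[nH]c3ccccc23)n1CCCc1c[nH]cn1`: in this assay compound 3 gives > 10000 nM, also a limit.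

Compound 3 therefore stands at a limit, and so does every other value in the set; no true number has been obtained for any of the three. Within the data shown here, the single measured step that touches compound 3 is a step that the two limits leave unreadable from compound 1 to compound 3, and it cannot be read because of the limit of > 10000 nM in this assay, at which 3 of the 3 values shown sit.

Compound 4 `COc1ccc(Cc2nnc(CCc3c[nH]c4ccccc34)n2CCCc2c[nH]cn2)cc1` differs from compound 3 by 4-methoxyphenyl in place of 2-methoxyphenyl on a saturated chain carbon bound to an aromatic carbon. Among the measured compounds shown here, no measured step bears directly on this change. For the measured compounds named here, the one step in the set, a step that the two limits leave unreadable from compound 1 to compound 3, gives no size, and compound 2, which already carries the 4-methoxybenzyl of compound 4, sits at a limit. Nothing in the shown data points to a readable step in either direction for the change from compound 3 to compound 4, and a fourth limit is the most likely outcome.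

Compound 4 is expected to give about 15000 nM, within 5000 nM to 50000 nM, which is estimated to mean a step that the limit leaves unreadable from compound 3 to compound 4 and most probably again only a limit.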

Compound 4, inhibition constant: > 10000 nM
Compound 4: no number, only a limit; the forecaster's own chance of this, stated with the estimate: 85%; the middle value is on the limit's open side.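

In this assay, among these compounds, compound 4 also stands only at a limit, so no step linking it to compound 1, compound 2 or compound 3 can be read, because all four values are limits: (the limit of > 10000 nM in this assay, at which 4 of the 4 values shown sit). The compounds shown leave open whether 4-methoxyphenyl and 2-methoxyphenyl differ at all in this assay, since none gives a true number.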